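Amide thiocyanate in place of the selenoester selenocyanate

The source may hold more compounds than are shown below. What is called first, only, known or untested is meant among the compounds shown, and "the series" means these compounds.

Compound 1 `CC(=O)Oc1ccccc1C(=O)NCC[Se]C#N` gives 3400 nM in a functional assay on HT-29 cells (Homo sapiens) for antiproliferative activity, read by MTT assay, with a stated time of 24 h; a higher number here means a weaker inhibitor, a lower number a stronger inhibitor. Compound 2 `CC(=O)Oc1ccccc1C(=O)OCC[Se]C#N` gives 10200 nM in this assay, which is a 3.0-fold higher number from compound 1 to compound 2 (0.48 log units; beyond the scatter). For compound 3 `CC(=O)Oc1ccccc1C(=O)[Se]CC[Se]C#N` the value > 50000 nM in this assay is a limit of the assay, not a number. Within the three measured values compound 3 therefore stands at the weak end, shown by an at least 14-fold higher number from compound 1 to compound 3 (1.16 log units; beyond the scatter) and an at least 4.9-fold higher number from compound 2 to compound 3 (0.69 log units; beyond the scatter), and it sits at the limit of > 50000 nM in this assay, at which 1 of the 3 values shown sits.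

Compound 4 `CC(=O)Oc1ccccc1C(=O)NCCSC#N` is not yet measured. Against compound 3 the change is a group of 6 heavy atoms (3 carbon, 2 nitrogen, 1 sulfur; no ring) in place of a group of 6 heavy atoms (3 carbon, 1 nitrogen, 2 selenium; no ring), on a carbonyl carbon. Compound 4 thus carries the amide linkage of compound 1 and differs from compound 1 only in sulfur rather than selenium within the cyanate group. The measured step that bears on this is an at least 14-fold higher number from compound 1 to compound 3 (1.16 log units; beyond the scatter), with an at least 4.9-fold higher number from compound 2 to compound 3 (0.69 log units; beyond the scatter) pointing the same way; reversing the selenoester-to-amide part of that change is expected to bring the number down. The expected step is an at least 8.3-fold lower number from compound 3 to compound 4 (0.92 log units; beyond the scatter) in this assay, toward a lower number. Compound 4 is estimated at 6000 nM, in a range from 2500 nM to 20000 nM.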

Compound 4, half-maximal inhibitory concentration: > 50000 nM
Compound 4: a limit, no number (the forecaster's own chance of this, stated with the estimate: 5%); middle value at least 8.3-fold (0.92 log units) away from the limit.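

The selenium of the selenocyanate end matters as well as the amide linkage: with the amide kept, the change to sulfur gives an at least 14-fold higher number from compound 1 to compound 4 (1.16 log units; beyond the scatter). Compound 2 has the ester linkage and keeps selenium, and it still gives a number, with an at least 4.9-fold higher number from compound 2 to compound 4 (0.69 log units; beyond the scatter), so in this assay the amide linkage alone does not hold the activity. Compound 4 reads only as a limit, and the step from compound 3 to compound 4 cannot be read: the limit of > 50000 nM in this assay, at which 2 of the 4 values shown sit.

On these data alone, how far compound 3 and compound 4 lie past that limit stays open, so the two cannot be ranked. Also open, as far as these compounds go, is whether the loss on going to sulfur holds with an amine or a carboxylic acid in place of the acetoxy group on the shared core, or with a longer chain carrying the selenocyanate.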